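Thiazolyl to 4-chlorophenyl on the amide nitrogen

A few compounds are considered here, and "the series" means these few. Any claim that something is new, unique, unknown or untested is made for them only; others in the source may bear on it.

Measured so far in a functional assay on HCT-116 cells (Homo sapiens) for antiproliferative activity, read by MTT assay, with a stated time of 72 h (a higher number here means a weaker inhibitor, a lower number a stronger inhibitor), as limits only:
- compound 1 `CCNC(=O)CCc1cccc2c1B(O)OC2` gives > 100000 nM
- compound 2 `O=C(CCc1cccc2c1B(O)OC2)Nc1nccs1` gives > 100000 nM

Compound 2 has no readable number, only the limit > 100000 nM in this assay for its place in the series. The measured set offers the limit of > 100000 nM in this assay, at which 2 of the 2 values shown sit, and nothing firmer. Compound 3 `O=C(CCc1cccc2c1B(O)OC2)Nc1ccc(Cl)cc1` brings one change, 4-chlorophenyl in place of 1,3-thiazol-2-yl on an amide-type nitrogen with the shared core kept. Among the measured compounds shown here, the one measured step on this nitrogen, a step that the two limits leave unreadable from compound 1 to compound 2 has no size to carry over, so it gives no ground for expecting a large gain. Only a small shift toward stronger inhibition is expected, and a result again reported as a limit is about as likely. The expected change is an at least 1.2-fold lower number from compound 2 to compound 3 (0.09 log units; that floor lies within the scatter) and it is only loosely estimated. For compound 3 the estimate is 80000 nM with an expected range from 20000 nM to 200000 nM in this assay for now.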

Compound 3, half-maximal inhibitory concentration: 12000 nM
Compound 3: the middle estimate sits 6.7-fold (0.82 log units) above what was measured; the measured number lies below the stated range.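

In this assay, among the compounds shown here, compound 3 gives the first readable number, so this place on the amide-type nitrogen does respond to the group it carries, which the earlier pair could not show. The 4-chlorophenyl group gives an at least 8.3-fold lower number from compound 2 to compound 3 (0.92 log units; beyond the scatter) against 1,3-thiazol-2-yl, and an at least 8.3-fold lower number from compound 1 to compound 3 (0.92 log units; beyond the scatter) against ethyl; the step between compound 1 and compound 2 cannot be read, and the other two values remain limits, not numbers: the limit of > 100000 nM in this assay, at which 2 of the 3 values shown sit.

As far as these compounds go, whether the step belongs to the chlorine or to the six-membered aromatic ring of carbon stays open, and a plain phenyl group on the same nitrogen would separate the two. From the compounds shown here alone, how far the number moves with other groups at this place, such as 4-methoxyphenyl or benzyl, also stays open.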